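The compounds below may be only part of what the source reports. "The series", "measured", "known", "first", "only" and "open" are said of these compounds alone.

Measured compounds:
Compound 1 `O=C(O)CCC[C@H](O)[C@@H](/C=C/CCc1ccccc1)Sc1ccc(C(=O)O)cc1` — in an assay on membranes from lung for binding affinity to cysteinyl leukotriene receptor 1 (Cavia porcellus) (on this read-out lower numbers stand for stronger inhibition and higher numbers for weaker inhibition), compound 1 gives < 100000 nM, a limit of the assay.
Compound 2 `O=C(O)CCC[C@H](O)[C@@H](/C=C\CCCCCCCCc1ccccc1)Sc1ccc(C(=O)O)cc1` — in this assay compound 2 gives 316 nM.

Going by the values given here, compound 2 stands alone as the only numeric value in this assay; the other entry, that of compound 1, is a limit and not a number (the limit of < 100000 nM in this assay, at which 1 of the 2 values shown sits). Among the compounds with values here, no step between two measured compounds is available, so nothing measured tells how far a change of the kind considered here moves the read-out.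

Compound 3 `O=C(O)CCC[C@H](O)[C@@H](/C=C\CCCCCCCCCCCc1ccccc1)Sc1ccc(C(=O)O)cc1` differs from compound 2 in one place: 3-phenylpropyl in place of phenyl on a saturated chain carbon, eight bonds along the chain from a double-bonded chain carbon. The chain that carries the terminal ring is therefore lengthened without any change to the shared core, the hydroxyl group, the two carboxylic acids or the thioether.

Within the data shown here, with no measured step to lean on, the expectation for compound 3 rests only on compound 2 at 316 nM: the step of a 1.1-fold lower number from compound 2 to compound 3 (0.02 log units; within the scatter) is expected to be small, if any, and not clearly beyond the usual scatter. Compound 3 is therefore estimated at 300 nM in this assay, within a range from 60 nM to 1500 nM.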

Compound 3, inhibition constant: 1260 nM
The estimate for compound 3 lay 4.2-fold (0.62 log units) below the measured number; measured number inside the range.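

Going by these compounds alone, the step of a 4.0-fold higher number from compound 2 to compound 3 (0.60 log units; beyond the scatter) is the first measured evidence on this position in this assay, and it shows that the read-out is not indifferent to what stands on this saturated chain carbon, eight bonds along the chain from a double-bonded chain carbon. Replacing phenyl with 3-phenylpropyl there, with the shared core, the hydroxyl group, the two carboxylic acids and the thioether all unchanged, gives weaker inhibition, so adding to the chain at this point does not improve on compound 2, although the step is modest in size. Within the data shown here, the one value available for this change offers no measured explanation of why the longer chain costs inhibition.

A single step cannot show whether the loss continues or levels off with a still longer chain such as 6-phenylhexyl on the same carbon, or whether a shorter chain such as benzyl in place of phenyl would give stronger inhibition. It also leaves open how the read-out would respond to a carboxylic acid or an amine at the end of this chain in place of the terminal phenyl ring.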